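This account rests on a few compounds, and the source may have more. Where it says the series, first, only, none or still open, it means among the compounds named here.

Of the compounds shown here, three built on a shared core have been tested in a functional assay on CWR22R cells (Homo sapiens) for antiproliferative activity, read by MTT assay, with a stated time of 3 days; on this read-out lower numbers stand for stronger inhibition and higher numbers for weaker inhibition. Compound 1 (`COc1cc(O)c2c(=O)cc(-c3ccc(NS(C)(=O)=O)cc3)oc2c1OC(C)C`) gives 3800 nM while compound 2 (`CCCS(=O)(=O)Nc1ccc(-c2cc(=O)c3c(O)cc(OC)c(OC(C)C)c3o2)cc1`) gives 2900 nM and compound 3 (`COc1cc(O)c2c(=O)cc(-c3ccc(NC(=O)NC4CC4)cc3)oc2c1OC(C)C`) gives 6700 nM in the same test. Compound 3 is clearly separated from only one of the other two. The step of a 2.3-fold higher number from compound 2 to compound 3 (0.36 log units; beyond the scatter) is the real gap, whereas the step of a 1.8-fold higher number from compound 1 to compound 3 (0.25 log units; within the scatter) cannot be told apart from repeat-to-repeat noise. The step of a 1.3-fold lower number from compound 1 to compound 2 (0.12 log units; within the scatter) is just as small.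

The next compound is compound 4 (`COc1cc(O)c2c(=O)cc(-c3ccc(NC(=O)N4CC(C)NC(C)C4)cc3)oc2c1OC(C)C`). It carries 3,5-dimethylpiperazin-1-yl in place of cyclopropylamino on a carbonyl carbon, and the change is counted as follows: 3,5-dimethylpiperazin-1-yl in place of cyclopropylamino on a carbonyl carbon (the rest of the molecule stays the same). Among the compounds with values here, no tested pair makes this exact swap, so the evidence is indirect. The closest guide is the set of changes to the group on the aromatic nitrogen, where the step of a 2.3-fold higher number from compound 2 to compound 3 (0.36 log units; beyond the scatter) is the only one beyond the scatter and is still modest. On that basis, the expected change is a 1.3-fold lower number from compound 3 to compound 4 (0.13 log units; within the scatter) and no step beyond the scatter is anticipated. For compound 4 the estimated value is 5000 nM with an expected range from 1800 nM to 12000 nM in this test.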

Compound 4, half-maximal inhibitory concentration: 800 nM
The estimate for compound 4 lay 6.3-fold (0.80 log units) above the measured number; the whole stated range lies above it.
By their numbers in this assay, from the lowest: compound 4; then compounds 2, 1 and 3 (each within the scatter of the next, the first and the last beyond it).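

In this assay, putting 3,5-dimethylpiperazin-1-yl in place of cyclopropylamino on this carbonyl carbon gives an 8.4-fold lower number from compound 3 to compound 4 (0.92 log units; beyond the scatter), a far larger step than any seen among the first three compounds, so the group held on this carbonyl carbon can strongly change the number. The new compound also stands clear of both sulfonyl compounds, with a 3.6-fold lower number from compound 2 to compound 4 (0.56 log units; beyond the scatter) and a 4.8-fold lower number from compound 1 to compound 4 (0.68 log units; beyond the scatter), which makes compound 4 the only one of the four whose steps to all the others lie beyond the scatter. No measurement available here accounts for this gain in inhibition.

The six-membered ring, its second nitrogen and its two methyl groups all arrive in a single change, so the compounds shown cannot say which of these parts matters. Plain piperazin-1-yl without the methyl groups, and morpholin-4-yl or piperidin-1-yl on the same carbonyl carbon, would begin to pull these parts apart.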